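Cyclobutylamino in Place of Diethylamino: Compound 4 Expected

The compounds below may be only part of what the source reports. "The series", "measured", "known", "first", "only" and "open" are said of these compounds alone.

In a functional assay on the whole organism for inhibition, with Rattus norvegicus as the target, at a dose of 25 mg/kg by the intraperitoneal route (on this read-out lower numbers stand for less inhibition and higher numbers for more inhibition at the one dose given (going by the name of the read-out)), compound 1 `CN(C)c1ncnc2c1ncn2Cc1ccc(F)cc1` gives 21%. Within the data shown here, compound 2 `CN(C)c1ncnc2c1ncn2Cc1ccc(O)cc1` gives 0%, and the one measured step in this set, a number 21 percentage points lower from compound 1 to compound 2 (beyond the scatter), is the only change seen on the numbers. Compound 3 `CCN(CC)c1ncnc2c1ncn2CC1CC1` gives 0% in this assay; it stands level with compound 2 at the digits shown, the two together holding the lowest of the three numbers, while compound 1 lies furthest from it.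

Compound 4 `c1nc(NC2CCC2)c2ncn(CC3CC3)c2n1` differs from compound 3 by cyclobutylamino in place of diethylamino on an aromatic carbon. Among the measured compounds shown here, the measured step concerns another group at another place, so no measured pair speaks to this exchange, and no step beyond the scatter is expected. Compound 4 is estimated at 5%, between 0% and 20%, a step of a number 5 percentage points higher from compound 3 to compound 4 (within the scatter) expected.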

Compound 4, a percentage reported as inhibition, in the whole organism at one dose (the size of the read-out at that dose, not a potency): 0%
The estimate for compound 4 lay 5 percentage points above the measured number; the range from low to high includes it.
By their numbers in this assay, from the lowest: compounds 2, 3 and 4 (each within the scatter of the next); then compound 1.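

In this assay, cyclobutylamino in place of diethylamino on an aromatic carbon gives no change at the digits printed from compound 3 to compound 4 (within the scatter). Among these compounds, this is the first measured exchange at this position: a group with a four-membered ring and a hydrogen-bond donor replaces one with neither, and the printed number stays the same. Nothing available here offers an explanation for this result. Going by these compounds, what the same exchange would give alongside the fluoro-bearing aromatic ring of compound 1 remains open, as does the outcome on this aromatic carbon for an unsubstituted amino group or a longer chain such as dibutylamino.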